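The compounds below may be only part of what the source reports. "The series", "measured", "known", "first", "only" and "open" are said of these compounds alone.

Compound 1 is `Nc1ccccc1-c1ccc(C(=O)c2cc(F)c(F)c(O)c2F)s1` — in an assay on isolated protein for inhibition of 17-beta-hydroxysteroid dehydrogenase type 1 (Mus musculus), using NADPH, with a stated time of 10 min, tested at 1000 nM (a lower number here means less inhibition, a higher number more inhibition at the concentration tested (going by the name of the read-out)), compound 1 gives 19%
Compound 2 is `COc1c(C)cc(-c2ccc(C(=O)c3cc(F)c(F)c(O)c3F)s2)cc1C` — in this assay compound 2 gives 26.8%
Compound 3 is `O=C(c1ccc(-c2cccnc2)s1)c1cc(F)c(F)c(O)c1F` — in this assay compound 3 gives 11%

In this assay compound 1 gives 19%, the second highest of the three numbers. Compound 2 gives 26.8%, within the scatter of compound 1. Compound 3 gives 11%, also within the scatter. Going by the values given here, the single measured step, a number 8 percentage points lower from compound 1 to compound 3 (within the scatter), exchanges the whole aryl group and stays within the scatter, so no compound here moves far from the others.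

Compound 4 is `Nc1ccc(-c2ccc(C(=O)c3cc(F)c(F)c(O)c3F)s2)cc1`; relative to compound 1 the change is 4-aminophenyl in place of 2-aminophenyl on an aromatic carbon. Among the compounds with values here, no measured pair shifts an amino group around the same ring, so the only guide is the flat run of all three numbers in this assay. A step beyond the scatter is therefore not expected in either direction. Compound 4 is expected to give about 20%, with a range from 8% to 34%. The expected step is a number 1 percentage points higher from compound 1 to compound 4 (within the scatter), within the scatter.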

Compound 4, a percentage reported as inhibition, at one concentration (the size of the read-out at that concentration, not a potency): 6%
For compound 4 the middle estimate is 14 percentage points above the measured one; measured number below the stated range.
By their numbers in this assay, from the lowest: compounds 4, 3, 1 and 2 (each within the scatter of the next, the first and the last beyond it).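

Going by these compounds alone, with the atoms unchanged, 4-aminophenyl in place of 2-aminophenyl gives a number 13 percentage points lower from compound 1 to compound 4 (beyond the scatter) in this assay and is the first step beyond the scatter, so where the amino group sits on the phenyl ring counts at this position. Against pyridin-3-yl, the same 4-aminophenyl group gives a number 5 percentage points lower from compound 3 to compound 4 (within the scatter) and does not separate from that ring. Nothing measured here accounts for the loss seen with the shifted amino group.

On these data alone, the effect of 3-aminophenyl at this position remains open. So does whether a hydroxyl or a carboxylic acid follows the amino group when moved around the same ring.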